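The compounds below may be only part of what the source reports. "The series", "measured", "known", "first", "only" and "open" are said of these compounds alone.

Measured so far:
Compound 1 `CC(=O)NS(=O)(=O)c1ccc(N/C(S)=N\c2ccnc3cc(C(F)(F)F)ccc23)cc1` gives 30000 nM
Compound 2 `O=S(=O)(Nc1ccccn1)c1ccc(N/C(S)=N\c2ccnc3cc(C(F)(F)F)ccc23)cc1` gives 87500 nM

Both were tested in a functional assay on LoVo cells (Homo sapiens) for antiproliferative activity, read by sulforhodamine B assay, with a stated time of 48 h; on this read-out higher numbers stand for weaker inhibition and lower numbers for stronger inhibition. Compound 2 stands at the highest number of the two; its nearest neighbour is compound 1, and the step of a 2.9-fold higher number from compound 1 to compound 2 (0.46 log units; beyond the scatter) followed a single change, pyridin-2-yl in place of acetyl on a sulfonamide nitrogen. Compound 3 `Cc1ccnc(NS(=O)(=O)c2ccc(N/C(S)=N\c3ccnc4cc(C(F)(F)F)ccc34)cc2)n1` has not yet been measured. It differs from compound 2 in one place: 4-methylpyrimidin-2-yl in place of pyridin-2-yl on a sulfonamide nitrogen. Among the measured compounds shown here, the only measured step at this sulfonamide nitrogen is a 2.9-fold higher number from compound 1 to compound 2 (0.46 log units; beyond the scatter), which was modest. For the measured compounds named here, no measured pair compares two aromatic rings at this position, so the expectation rests on that one step and stays cautious. Compound 3 is expected to differ from compound 2 by a 1.5-fold lower number from compound 2 to compound 3 (0.16 log units; within the scatter), a change that may well stay within the scatter. Compound 3 is therefore estimated at 60000 nM, with a range from 20000 nM to 200000 nM.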

Compound 3, half-maximal inhibitory concentration: 31000 nM
The estimate for compound 3 lay 1.9-fold (0.29 log units) above the measured number, within the range that was stated.
By their numbers in this assay, from the lowest: compounds 1 and 3 (each within the scatter of the next); then compound 2.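

Among the compounds shown here, this is the first comparison of two aromatic rings on the sulfonamide nitrogen, and in this assay the choice of ring makes a modest difference: 4-methylpyrimidin-2-yl in place of pyridin-2-yl gives a 2.8-fold lower number from compound 2 to compound 3 (0.45 log units; beyond the scatter) and lies beyond the scatter. The acetyl group and 4-methylpyrimidin-2-yl cannot be told apart on this read-out, with a 1.0-fold higher number from compound 1 to compound 3 (0.01 log units; within the scatter) and within the scatter, so among these three groups only the pyridin-2-yl of compound 2 stands apart. No measurement shown here offers a reason for either step.

The change brings a second ring nitrogen and a methyl together, so the compounds shown leave open which of the two goes with the step; plain pyrimidin-2-yl would separate them. Also open, going by these compounds, is how a longer acyl chain such as butanoyl would read at this nitrogen.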